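The compounds below may be only part of what the source reports. "The series", "measured", "known", "first", "only" and "open" are said of these compounds alone.

Compound 1 `O=C(Nc1cccc(-c2oc3cc(-c4ccc(F)cc4)ccc3c(=O)c2O)c1)c1ccc(Cl)cc1` gives 3670 nM in a functional assay on HeLa cells (Homo sapiens) for antiproliferative activity, read by CCK-8 assay, with a stated time of 72 h; a lower number here means a stronger inhibitor, a higher number a weaker inhibitor. For the measured compounds named here, compound 2 `N#Cc1ccc(C(=O)Nc2cccc(-c3oc4cc(-c5ccc(F)cc5)ccc4c(=O)c3O)c2)cc1` gives 23300 nM in this assay, the higher of the two numbers measured so far; its nearest neighbour is compound 1, separated by the step of a 6.3-fold higher number from compound 1 to compound 2 (0.80 log units; beyond the scatter), which is the only measured step. Compound 3 `O=C(Nc1cccc(-c2oc3cc(-c4ccc(F)cc4)ccc3c(=O)c2O)c1)c1ccc([N+](=O)[O-])cc1` has not been measured. Relative to compound 2 the change is nitro in place of cyano on an aromatic carbon, on the same aromatic carbon of the 4-cyanophenyl group that the earlier step altered. Going by the values given here, that earlier step concerned a halogen giving way to cyano, not cyano giving way to nitro, so no measured step bears directly on this swap and its direction is open. With nothing to anchor a shift, compound 3 is expected to stay close to compound 2, with a step of a 1.2-fold lower number from compound 2 to compound 3 (0.07 log units; within the scatter) in this assay. The estimate for compound 3 is 20000 nM, within a range of 6000 nM to 65000 nM.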

Compound 3, half-maximal inhibitory concentration: 12300 nM
The estimate for compound 3 lay 1.6-fold (0.21 log units) above the measured number; low and high end bracket the measured number.
By their numbers in this assay, from the lowest: compound 1; then compounds 3 and 2 (each within the scatter of the next).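

In this assay, nitro in place of cyano gives a 1.9-fold lower number from compound 2 to compound 3 (0.28 log units; within the scatter), so this swap at the aromatic carbon does not separate compound 2 from compound 3. Nitro in place of chloro gives a 3.4-fold higher number from compound 1 to compound 3 (0.53 log units; beyond the scatter), and with this step compound 1 stands as the strongest of the three, with both the cyano and the nitro replacement of its chloro lying beyond the scatter from it. No measurement to hand accounts for the difference between chloro and the other two groups.

The compounds shown leave open whether an amine, a methoxy group or a carboxylic acid on this same aromatic carbon would fall with compound 1 or with compound 2 and compound 3. They also leave open whether fluoro or bromo would keep the number of compound 1.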